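Furan-2-yl in Place of Thiophen-3-yl: Two Matched Pairs

A few compounds are considered here, and "the series" means these few. Any claim that something is new, unique, unknown or untested is made for them only; others in the source may bear on it.

The measured compounds:
Compound 1, `Oc1ccc(-c2cc(-c3ccc(Cl)cc3)nc(-c3ccsc3)c2)cc1`, 47.7%
Compound 2, `Oc1ccc(-c2cc(-c3ccc(Cl)cc3)nc(-c3ccco3)c2)cc1`, 15.8%
Compound 3, `Oc1cccc(-c2cc(-c3ccsc3)nc(-c3ccccc3Cl)c2)c1`, 0%

Of the compounds shown here, three have been tested in an assay on isolated protein for inhibition of DNA topoisomerase 1 (Homo sapiens), with a stated time of 30 min, tested at 100 uM; a higher number here means a stronger effect of the compound at the concentration tested, a lower number a weaker effect. Compound 1 gives 47.7% in this assay. Compound 2 gives 15.8%, and compound 3 gives 0%, the lowest of the three numbers, beyond the scatter from both others.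

Compound 2 differs from compound 1 by one change, (furan-2-yl in place of thiophen-3-yl on an aromatic carbon), and this change produced a number 31.9 percentage points lower from compound 1 to compound 2 (beyond the scatter). Compound 3 has the same atoms as compound 1 joined differently; the difference between the two cores is not broken down here.

Compound 4, `Oc1cccc(-c2cc(-c3ccco3)nc(-c3ccccc3Cl)c2)c1`, has not been measured. Among the measured compounds shown here, it arises from compound 3 by furan-2-yl in place of thiophen-3-yl on an aromatic carbon, the same kind of change as the one from compound 1 to compound 2, but the surroundings differ: in compound 3 the changed carbon is meta to a 2-chlorophenyl group and meta to a 3-hydroxyphenyl group, while in compound 1 it is meta to a 4-chlorophenyl group and meta to a 4-hydroxyphenyl group. For the measured compounds named here, the one precedent points downward, yet a further fall cannot show because compound 3 already gives 0%. The step from compound 3 to compound 4 is therefore expected to be a number 2 percentage points higher from compound 3 to compound 4 (within the scatter). Compound 4 is estimated at 2%, expected to lie between 0% and 15%.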

Compound 4, a percentage reported as inhibition, at one concentration (the size of the read-out at that concentration, not a potency): 0%
The estimate for compound 4 lay 2 percentage points above the measured number; the range from low to high includes it.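

In this assay, furan-2-yl in place of thiophen-3-yl does not give the same result on the two cores: the same change on two cores in this assay, a number 31.9 percentage points lower (beyond the scatter) from compound 1 to compound 2 and no change at the digits printed (within the scatter) from compound 3 to compound 4, 31.9 percentage points apart, beyond the scatter of two such steps

On the core of compound 3 the new step is no change at the digits printed from compound 3 to compound 4 (within the scatter), and since compound 3 already stands at the bottom of the read-out, a fall like the one on the core of compound 1 could not have appeared there. The pair of compound 3 and compound 4 therefore shows that the effect of the change cannot be read across to this second core, but it does not show that the change is harmless there, nor does it show which difference between the cores matters, since the chlorophenyl and hydroxyphenyl groups differ together.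

Going by these compounds, what the change does on a further core with a number clearly above the bottom of the read-out remains open, as two pairs cannot settle that. The compounds shown also leave open how an amine or a carboxylic acid in place of the hydroxyl group, or a longer chain on either core, would read in this assay.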